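The compounds below may be only part of what the source reports. "The series", "measured", "known", "first", "only" and "open" are said of these compounds alone.

In an in vivo ADME assay on the whole organism (strain Sprague-Dawley) for pharmacokinetics, with Rattus norvegicus as the target, at a dose of 10 mg/kg by the oral route (a higher number here means more compound in the circulation at the dose given, a lower number less compound in the circulation), compound 1 `COc1c(NC(=O)c2cc3cccc(NC(=O)c4ccc(NC5CC5)nc4)c3s2)cc(C(C)(C)C)cc1NS(C)(=O)=O` gives 3950 nM, the lower of the two numbers at hand, while compound 2 `COc1c(NC(=O)c2cc3cccc(NC(=O)c4cccnc4)c3n2C)cc(C(C)(C)C)cc1NS(C)(=O)=O` gives 16400 nM, a gap beyond the usual scatter. Compound 3 `COc1c(NC(=O)c2cc3cccc(NC(=O)c4cccnc4)c3s2)cc(C(C)(C)C)cc1NS(C)(=O)=O` has not yet been measured. Against compound 1 the change is hydrogen in place of cyclopropylamino on an aromatic carbon. For the measured compounds named here, no measured pair isolates this single change, and compound 2 differs from compound 1 in more than one place. A modest step, a 1.5-fold higher number from compound 1 to compound 3 (0.18 log units; within the scatter), is expected, leaning upward. Compound 3 is therefore estimated at 6000 nM, within a range from 2000 nM to 18000 nM.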

Compound 3, maximal plasma concentration: 9410 nM
Beside the measured number, compound 3's estimate is 1.6-fold (0.20 log units) below it; the measured number falls inside the stated range.
By their numbers in this assay, from the lowest: compound 1; then compounds 3 and 2 (each within the scatter of the next).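

In this assay, replacing cyclopropylamino with hydrogen on the aromatic carbon next to the ring nitrogen gives a 2.4-fold higher number from compound 1 to compound 3 (0.38 log units; beyond the scatter) within an otherwise unchanged structure. This single-change pair shows that the group at this position affects how much compound reaches the circulation, with hydrogen giving the higher number. Nothing available here explains the step.

From the compounds shown here alone, it remains open whether a smaller amine such as methylamino, or a methoxy group, at the same position would give a number closer to that of compound 1 or compound 3.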